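The compounds below may be only part of what the source reports. "The series", "measured", "known", "first", "only" and "open" are said of these compounds alone.

Compound 1 `CCCCOc1ccc(-c2nc3ncccn3c2NC2CCCCCC2)cc1`; compound 2 `CCCCOc1ccc(-c2nc3ncccn3c2Nc2ccc(F)cc2)cc1`; compound 3 `CCNC(=O)CCCOc1ccc(-c2nc3ncccn3c2NC2CCCCC2)cc1`.

In a toxicity assay on A549 cells (Homo sapiens) for cytotoxicity, read by luminescence and CellTiter-Glo, with a stated time of 48 h (on this read-out higher numbers stand for lower toxicity in this test and lower numbers for higher toxicity in this test), compound 1 gives 26000 nM. For compound 2 the result is a limit of the assay, > 100000 nM. For compound 3 the result is likewise a limit of the assay, > 100000 nM. Compound 3 thus stands at the limit of > 100000 nM in this assay, at which 2 of the 3 values shown sit, rather than at a number.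

Compound 4 `Clc1ccc(-c2nc3ncccn3c2NC2CCCCC2)cc1` differs from compound 3 by chloro in place of 3-(ethylcarbamoyl)propoxy on an aromatic carbon. Among the compounds with values here, the only measured step, an at least 3.8-fold higher number from compound 1 to compound 2 (0.58 log units; beyond the scatter), alters the group on a nitrogen on an aromatic ring, not the substituent on the carbon ring, so it does not bear on this change, and compound 1 and compound 3 differ in two places. Compound 4 is therefore expected near 40000 nM, between 12000 nM and 100000 nM. That estimate implies an at least 2.5-fold lower number from compound 3 to compound 4 (0.39 log units; beyond the scatter).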

Compound 4, half-maximal cytotoxic concentration: > 100000 nM
Compound 4: no number, only a limit (the forecaster's own chance of this, stated with the estimate: 40%); at least 2.5-fold (0.39 log units) between middle value and limit.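

Compound 3 and compound 4 both sit at a limit of the assay, so no step between them can be read: the limit of > 100000 nM in this assay, at which 3 of the 4 values shown sit.

The compounds shown leave open whether chloro in place of 3-(ethylcarbamoyl)propoxy changes the read-out at all.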